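Amide nitrogen substituents on the shared core: the carboxyphenyl step

This account rests on a few compounds, and the source may have more. Where it says the series, first, only, none or still open, it means among the compounds named here.

The series keeps one core and varies the group on the amide-type nitrogen. Compound 1 `CNC(=O)c1nc(-c2cc(OC)c(OC)c(OC)c2)n(-c2ccc(OC)cc2)n1` carries methyl there; in a functional assay on the whole organism for inhibition, with Rattus norvegicus as the target, read by paw edema, with stated times of 30 min and 3 h, at a dose of 0.28 mmol/kg by the oral route (a lower number here means less inhibition, a higher number more inhibition at the dose given (going by the name of the read-out)), compound 1 gives 74%. Compound 2 `CCNC(=O)c1nc(-c2cc(OC)c(OC)c(OC)c2)n(-c2ccc(OC)cc2)n1` carries ethyl, and in this assay compound 2 gives 69%. Compound 3 `COc1ccc(-n2nc(C(=O)Nc3ccccc3C)nc2-c2cc(OC)c(OC)c(OC)c2)cc1` carries 2-methylphenyl, and in this assay compound 3 gives 50%.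

Compound 2 stands together with compound 1 at the upper end of the three values, the two lying within the scatter of each other, as the step of a number 5 percentage points lower from compound 1 to compound 2 (within the scatter) shows. Toward compound 3 the gap is real: a number 19 percentage points lower from compound 2 to compound 3 (beyond the scatter), and from the methyl compound the same kind of change reads a number 24 percentage points lower from compound 1 to compound 3 (beyond the scatter).

Compound 4 `COc1ccc(-n2nc(C(=O)Nc3ccc(C(=O)O)cc3)nc2-c2cc(OC)c(OC)c(OC)c2)cc1` is the next member. Relative to compound 2 the change is 4-carboxyphenyl in place of ethyl on an amide-type nitrogen. Within the data shown here, the steps that bear on it are those from a small alkyl to an aryl group on the same nitrogen, both of modest size and both downward. Among the measured compounds shown here, a downward step in this assay from compound 2 to compound 4 is therefore expected, of roughly the size seen with the other aryl amide, although the carboxyl group on the entering ring has no counterpart among the measured compounds. For compound 4 the expected value is 52%, with a range from 36% to 68%; the expected step is a number 17 percentage points lower from compound 2 to compound 4 (beyond the scatter).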

Compound 4, a percentage reported as inhibition, in the whole organism at one dose (the size of the read-out at that dose, not a potency): 74%
Compound 4: middle estimate off by 22 percentage points, on the low side; the measured number lies above the stated range.
By their numbers in this assay, from the lowest: compound 3; then compounds 2, 1 and 4 (each within the scatter of the next).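

An aryl group on the amide-type nitrogen does not in itself go with a lower number in this assay: the change to 4-carboxyphenyl gives a number 24 percentage points higher from compound 3 to compound 4 (beyond the scatter), so the lower reading seen so far belongs to 2-methylphenyl and not to aryl amides as a class. Compound 4 instead stands with the small alkyl amides, with a number 5 percentage points higher from compound 2 to compound 4 (within the scatter) and no change at the digits printed from compound 1 to compound 4 (within the scatter), so at this one dose the position takes 4-carboxyphenyl, with its 9 heavy atoms and one six-membered aromatic ring, in place of ethyl or methyl without a step beyond the scatter. Nothing at hand accounts for the gap between the two aryl amides.

The two aryl groups differ both in the substituent and in its place on the ring, so phenyl, 4-methylphenyl and 2-carboxyphenyl on the same nitrogen would be needed to separate these two changes. On these data alone, whether the free carboxylic acid matters stays open too, a question for the methyl ester of compound 4 or for a carboxymethyl group on the amide-type nitrogen.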